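The source may report more compounds than this note shows. Statements on the series, on what has been measured and on what is new or still open speak of the compounds shown alone.

Compound 1 `CN1CCN(CCCOc2c(O)cc(O)c3c(=O)cc(-c4ccccc4)oc23)CC1`: > 100000 nM
Compound 2 `O=c1cc(-c2ccccc2)oc2c(OCCNCCO)c(O)cc(O)c12`: "not determined" (no result reported)
Compound 3 `CCCNCCOc1c(O)cc(O)c2c(=O)cc(-c3ccccc3)oc12`: "not determined" (no result reported)

The test here is a functional assay on A549 cells (Homo sapiens) for cytotoxicity, read by MTT assay, with a stated time of 48 h; on this read-out lower numbers stand for stronger inhibition and higher numbers for weaker inhibition. On this assay, compound 3 has no number to its name, and compound 2 has none either. Compound 1 gives > 100000 nM, which is a limit of the assay and not a number.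

The next compound to be measured is compound 4 `CN(C)CCCCOc1c(O)cc(O)c2c(=O)cc(-c3ccccc3)oc12`. The change is 2-(dimethylamino)ethyl in place of propylamino on a saturated chain carbon, two bonds along the chain from an oxygen on an aromatic ring, which can also be read as 2-(propylamino)ethoxy to 4-(dimethylamino)butoxy. With compound 3 unmeasured, no size or direction of step can be expected beyond the scatter. For the measured compounds named here, the only guide is compound 1, with the limit of > 100000 nM in this assay, at which 1 of the 3 values shown sits, so compound 4 is expected to be weak too. Compound 4 is estimated at 70000 nM, within a range of 25000 nM to 200000 nM.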

Compound 4, half-maximal inhibitory concentration: > 100000 nM
Compound 4: no number, only a limit; the forecaster's own chance of this, stated with the estimate: 50%; middle value at least 1.4-fold (0.15 log units) from the limit.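

No step can be read from compound 1 to compound 4, as each gives only a limit of the assay and not a number. The compounds shown leave open whether any of these side chains on the shared core gives a measurable value.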